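Bromo to chloro on the benzamide aryl ether

The source may report more compounds than this note shows. Statements on the series, on what has been measured and on what is new or still open speak of the compounds shown alone.

Compound 1 `Nc1ccccc1NC(=O)c1ccc(COc2ccc(Br)cc2)cc1` sits at the edge of the assay: in a functional assay on HepG2 cells (Homo sapiens) for antiproliferative activity, read by CCK-8 assay, with a stated time of 72 h (a lower number here means a stronger inhibitor, a higher number a weaker inhibitor), compound 1 gives > 32000 nM, a limit rather than a number. Compound 2 `Nc1ccccc1NC(=O)/C=C/c1ccc(CN2CCc3ccccc32)cc1` likewise reaches only a limit in this assay, giving > 32000 nM. Compound 3 `C/C(=N\O)c1ccc(OCc2ccc(C(=O)NO)cc2)cc1` gives 7770 nM in this assay. The series thus gathers at the limit of > 32000 nM in this assay, at which 2 of the 3 values shown sit, with compound 3 alone supplying a number. Within the data shown here, no measured step between compounds differing in a single place is available, so compound 1 is placed only by its limit, alongside compound 2. Compound 4 `Nc1ccccc1NC(=O)c1ccc(COc2ccc(Cl)cc2)cc1` differs from compound 1 by chloro in place of bromo on an aromatic carbon. The estimated step is a step that the limit leaves unreadable from compound 1 to compound 4, with no change beyond the scatter expected in this assay and a limit rather than a number likely again. Compound 4 is expected to give about 40000 nM, in the range 15000 nM to 100000 nM.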

Compound 4, half-maximal inhibitory concentration: > 32000 nM
Compound 4 was reported as a limit; the forecaster's own chance of this, stated with the estimate: 85%; the middle value is on the limit's open side.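

Compound 1 and compound 4 both end in limits rather than numbers, so no step between them can be read: the limit of > 32000 nM in this assay, at which 3 of the 4 values shown sit.

Going by these compounds, how 4-bromophenoxy and 4-chlorophenoxy compare on the shared core remains open.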